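Halogen changes on the aryl ring of lipoyl-triazole coumarins

This account rests on a few compounds, and the source may have more. Where it says the series, first, only, none or still open, it means among the compounds named here.

The measured compounds:
compound 1 `COc1ccc(-c2cc3ccc(OCCCCn4cc(CNC(=O)CCCCC5CCSS5)nn4)cc3oc2=O)cc1` gives 44.9%;
compound 2 `O=C(CCCCC1CCSS1)NCc1cn(CCCCOc2ccc3cc(-c4ccc(Br)cc4)c(=O)oc3c2)nn1` gives 40.5%;
compound 3 `O=C(CCCCC1CCSS1)NCc1cn(CCCCOc2ccc3cc(-c4ccc(Cl)cc4)c(=O)oc3c2)nn1` gives 52%.

All three were tested in a functional assay on PC-12 cells (Rattus norvegicus) for cytotoxicity, read by MTT assay, with stated times of 3 h and 2 h, tested at 5 uM; a higher number here means a stronger effect of the compound at the concentration tested, a lower number a weaker effect. Compound 3 holds the highest of the three numbers, though only its gap to compound 2, a number 11.5 percentage points higher from compound 2 to compound 3 (beyond the scatter), lies beyond the scatter; the gap a number 7.1 percentage points higher from compound 1 to compound 3 (within the scatter) does not. Compound 4 `O=C(CCCCC1CCSS1)NCc1cn(CCCCOc2ccc3cc(-c4ccc(Cl)c(Cl)c4)c(=O)oc3c2)nn1` differs from compound 3 by chloro in place of hydrogen on an aromatic carbon. Among the measured compounds shown here, no measured step exchanges a hydrogen for chloro, so only the halogen exchanges, a number 4.4 percentage points lower from compound 1 to compound 2 (within the scatter) and a number 11.5 percentage points higher from compound 2 to compound 3 (beyond the scatter), bear on it, and both are small. Compound 4 is therefore expected to sit close to compound 3, with a step of a number 1 percentage points higher from compound 3 to compound 4 (within the scatter) that is not expected to exceed the scatter. The estimate for compound 4 is 53%, in the range 39% to 67%.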

Compound 4, a percentage reported as activity, at one concentration (the size of the read-out at that concentration, not a potency): 53.2%
Compound 4: the middle estimate sits 0.2 percentage points below what was measured; the range from low to high includes it.
By their numbers in this assay, from the lowest: compounds 2, 1, 3 and 4 (each within the scatter of the next, the first and the last beyond it).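

Adding a chloro ortho to the existing chloro, turning 4-chlorophenyl into 3,4-dichlorophenyl, moves the read-out in this assay only slightly (a number 1.2 percentage points higher from compound 3 to compound 4 (within the scatter)), so this position accepts a second halogen with no readable change. As whole-group exchanges, the 3,4-dichlorophenyl of compound 4 stands apart from 4-bromophenyl (a number 12.7 percentage points higher from compound 2 to compound 4 (beyond the scatter)) but not from 4-methoxyphenyl (a number 8.3 percentage points higher from compound 1 to compound 4 (within the scatter)). Nothing available explains these numbers. From the compounds shown here alone, what an amine, a carboxylic acid or a fluoro on this same aromatic carbon would do remains open.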